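Ethyl for Hydroxy on Two Related Cores

The source may report more compounds than this note shows. Statements on the series, on what has been measured and on what is new or still open speak of the compounds shown alone.

Compound 1, `O=C1CCC(N2C(=O)c3ccc(Nc4ccc(O)cc4)cc3C2=O)C(=O)N1`: 4%
Compound 2, `CCc1ccc(Nc2ccc3c(c2)C(=O)N(C2CCC(=O)NC2=O)C3=O)cc1`: 5%
Compound 3, `O=C1CCC(N2C(=O)c3cccc(Nc4ccc(O)cc4)c3C2=O)C(=O)N1`: 4%

All three were tested in an assay on FRT-Jurkat cells for inhibition of nuclear factor NF-kappa-B complex (Homo sapiens), read by flow cytometry, with a stated time of 24 h, tested at 10 uM; a higher number here means more inhibition at the concentration tested (going by the name of the read-out), a lower number less inhibition. Compound 1 gives 4% and compound 2 gives 5%; the change between them is ethyl in place of hydroxy on an aromatic carbon, and it produced a number 1 percentage points higher from compound 1 to compound 2 (within the scatter). Compound 3 shares its atoms with compound 1 but has them joined differently; the difference between the two cores is not broken down here. In this assay compound 3 gives 4%.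

Compound 4, `CCc1ccc(Nc2cccc3c2C(=O)N(C2CCC(=O)NC2=O)C3=O)cc1`, is not yet measured. Among the measured compounds shown here, it differs from compound 3 by ethyl in place of hydroxy on an aromatic carbon, which is the same change as the one from compound 1 to compound 2, at the same kind of place. For the measured compounds named here, the step is expected to be a number 1 percentage points higher from compound 3 to compound 4 (within the scatter) because a number 1 percentage points higher from compound 1 to compound 2 (within the scatter) is the only measured instance of this change. Compound 4 is therefore estimated at 5%, expected between -5% and 15%.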

Compound 4, a percentage reported as inhibition, at one concentration (the size of the read-out at that concentration, not a potency): 17%
Compound 4: the middle estimate sits 12 percentage points below what was measured; the measured number lies above the stated range.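

In this assay, among the compounds shown here, putting ethyl in place of hydroxy gives a number 13 percentage points higher from compound 3 to compound 4 (beyond the scatter), and this is the only one of the two steps that stands clear of the scatter. Set beside the earlier step, the gap between them is no larger than two such steps can show by chance: the same change on two cores in this assay, a number 1 percentage points higher (within the scatter) from compound 1 to compound 2 and a number 13 percentage points higher (beyond the scatter) from compound 3 to compound 4, 12 percentage points apart, within the scatter of two such steps. The data therefore show no real difference in how the change behaves on the two cores, but two steps cannot prove that it behaves alike on both.

The compounds shown leave open what other groups would do in this spot on the phenyl ring, such as an amine, a carboxylic acid or a longer chain like propyl. From the compounds shown here alone, each number is also read at one concentration only, so potency remains open.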